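A few compounds are considered here, and "the series" means these few. Any claim that something is new, unique, unknown or untested is made for them only; others in the source may bear on it.

Working notes on the series. The shared core is that of compound 1 `O=c1cc(/C=N\O)c2c(OCc3ccccc3)cc(OCc3ccccc3)cc2o1`, which carries a hydroxy on a double-bonded nitrogen. In a functional assay, read by spectrophotometry, with a stated time of 1 h (on this read-out higher numbers stand for weaker inhibition and lower numbers for stronger inhibition), compound 1 is recorded as "not active" (no number reported), with no number attached, so it stands outside the measured scale. Compound 3 `O=c1cc(/C=N\O)c2ccc(OCc3ccccc3)cc2o1` is a close relative that keeps the hydroxy on the double-bonded nitrogen. In this assay compound 3 reaches only a limit, > 2000000 nM, which is not a number. Compound 2 `O=c1cc(/C=N\Nc2ccc([N+](=O)[O-])cc2[N+](=O)[O-])c2ccc(OCc3ccccc3)cc2o1` instead carries a (2,4-dinitrophenyl)amino on that nitrogen; in this assay compound 2 gives 1970000 nM, a figure that sits close to the limit of > 2000000 nM in this assay, at which 1 of the 3 values shown sits.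

Compound 4 `O=c1cc(/C=N\Nc2ccc([N+](=O)[O-])cc2)c2c(OCc3ccccc3)cc(OCc3ccccc3)cc2o1` is the member still to be measured: (4-nitrophenyl)amino in place of hydroxy on a double-bonded nitrogen. Among the compounds with values here, compound 1 has no number, so no step from compound 1 to compound 4 can be sized from the data. The nearest guide is the pair compound 3 and compound 2, whose values show a limit and a figure just under it. From this change no step beyond the scatter is expected in this assay, in either direction. Compound 4 is expected to give about 2000000 nM, within 900000 nM to 4000000 nM, with a fair chance that only a limit is reported.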

Compound 4, half-maximal inhibitory concentration: 97900 nM
Beside the measured number, compound 4's estimate is 20-fold (1.31 log units) above it, and the stated range ends above it.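

In this assay, within the data shown here, compound 1 is recorded as "not active" (no number reported) and compound 4 gives 97900 nM on the same read-out, so no step between these two compounds can be read. Nothing shown accounts for the value of compound 4. The compounds shown leave open how hydroxy and (4-nitrophenyl)amino compare in size on the shared core of compound 1.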